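This account rests on a few compounds, and the source may have more. Where it says the series, first, only, none or still open, it means among the compounds named here.

Compound 1 `CCCCc1cn(-c2ccc(NC(=O)Nc3ccccc3C)cc2)nn1`: 300 nM
Compound 2 `CCCCc1cn(-c2ccc(NC(=O)Nc3cccc(F)c3)cc2)nn1`: 600 nM
Compound 3 `COc1cc(NC(=O)Nc2ccccc2C(F)(F)F)ccc1-n1cc(CCC(C)C)nn1`: 300 nM

Going by the values given here, in an assay for inhibition of ATP-dependent RNA helicase DDX3X (Homo sapiens), read by FRET, with a stated time of 40 min, in the presence of a further agent that is not named here (a lower number here means a stronger inhibitor, a higher number a weaker inhibitor), compound 1 gives the same figure as compound 3, and the only single-place step, a 2.0-fold higher number from compound 1 to compound 2 (0.30 log units; within the scatter), stays within the scatter, so the three numbers are not separated. Compound 4 `CCCCc1cn(-c2ccc(NC(=O)Nc3ccccc3NS(C)(=O)=O)cc2)nn1` differs from compound 1 by methanesulfonamido in place of methyl on an aromatic carbon. Among the compounds with values here, no measured step exchanges a group at this position for a methanesulfonamido, so none bears directly on it; the one step in hand, from compound 1 to compound 2, was small. Compound 4 is therefore expected to stay near compound 1, with an estimated step of a 1.3-fold higher number from compound 1 to compound 4 (0.12 log units; within the scatter). The estimate for compound 4 in this assay is 400 nM, within a range of 120 nM to 1300 nM.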

Compound 4, half-maximal inhibitory concentration: 60 nM
Beside the measured number, compound 4's estimate is 6.7-fold (0.82 log units) above it; measured number below the stated range.
By their numbers in this assay, from the lowest: compound 4; then compounds 1, 3 and 2 (each within the scatter of the next).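

In this assay, the aromatic carbon ortho to a large group proved able to shift the number beyond the scatter, with methanesulfonamido in place of methyl giving a 5.0-fold lower number from compound 1 to compound 4 (0.70 log units; beyond the scatter). The only earlier single-place step (a 2.0-fold higher number from compound 1 to compound 2 (0.30 log units; within the scatter)) stayed within the scatter, so this is the first change shown that separates two compounds. Nothing measured here accounts for the shift.

The compounds shown leave open which part of methanesulfonamido carries the shift. An amine, an acetamido or a methyl sulfone on this carbon would bear on that question.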